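The compounds below may be only part of what the source reports. "The series", "measured", "known", "first", "only" and "open" are said of these compounds alone.

In an assay on HEK293 cells for inhibition of Voltage-dependent T-type calcium channel subunit alpha-1G (Homo sapiens), read by fluorescence, tested at 10 uM (on this read-out lower numbers stand for less inhibition and higher numbers for more inhibition at the one concentration tested (going by the name of the read-out)), compound 3 `CCCc1nc(-c2ccccc2)c(CNCCN2CCN(c3cccc(C(F)(F)F)c3)CC2)o1` gives 56.3%, the lowest of the three numbers, although only part of that gap is beyond the scatter: compound 1 `CCCc1nc(-c2ccccc2)c(CNCCN2CCN(c3ccccc3Cl)CC2)o1` gives 60.1%, with a number 3.8 percentage points lower from compound 1 to compound 3 (within the scatter), while compound 2 `CCCc1nc(-c2ccccc2)c(CNCCN2CCN(c3cccc(C)c3C)CC2)o1` gives 66.7%, with a number 10.4 percentage points lower from compound 2 to compound 3 (beyond the scatter). Compound 4 `CCCc1nc(-c2ccccc2)c(CNCCN2CCN(c3ccccc3)CC2)o1` differs from compound 3 by hydrogen in place of trifluoromethyl on an aromatic carbon. Among the compounds with values here, no measured step strips the aryl ring bare; the two steps that bear on it, a number 3.8 percentage points lower from compound 1 to compound 3 (within the scatter) and a number 10.4 percentage points lower from compound 2 to compound 3 (beyond the scatter), swap one substituted phenyl for another and stay small, so only a small step in this assay is expected here, likely upward but not required to clear the scatter. The expected outcome is a number 2.7 percentage points higher from compound 3 to compound 4 (within the scatter). Compound 4 is estimated at 59%, between 46% and 72%.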

Compound 4, a percentage reported as inhibition, at one concentration (the size of the read-out at that concentration, not a potency): 54.3%
For compound 4 the middle estimate is 4.7 percentage points above the measured one; the range from low to high includes it.
By their numbers in this assay, from the lowest: compounds 4, 3, 1 and 2 (each within the scatter of the next, the first and the last beyond it).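

Hydrogen in place of trifluoromethyl on this aromatic carbon leaves the number in this assay within the scatter (a number 2 percentage points lower from compound 3 to compound 4 (within the scatter)), so the bare phenyl ring holds level with this substituted ring. The same holds against the 2-chlorophenyl ring (a number 5.8 percentage points lower from compound 1 to compound 4 (within the scatter)), and only the 2,3-dimethylphenyl ring stands clear of bare phenyl (a number 12.4 percentage points lower from compound 2 to compound 4 (beyond the scatter)). No measurement here gives a reason for these steps.
From the compounds shown here alone, whether an amine or a carboxylic acid on this aromatic carbon would move the number beyond the scatter stays open.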